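Swapping the cinnamamide aryl group on a trimethoxybenzophenone core

The source may hold more compounds than are shown below. What is called first, only, known or untested is meant among the compounds shown, and "the series" means these compounds.

Measured so far in a functional assay on HT-29 cells (Homo sapiens) for cytotoxicity, read by MTT assay, with a stated time of 72 h; on this read-out lower numbers stand for stronger inhibition and higher numbers for weaker inhibition:
Compound 1, `COc1ccc(C(=O)c2cc(OC)c(OC)c(OC)c2)cc1NC(=O)/C=C/c1ccc(OC)c(OC)c1`, gives 2500 nM.
Compound 2, `COc1ccc(C(=O)c2cc(OC)c(OC)c(OC)c2)cc1NC(=O)/C=C/c1cccc(OC(F)(F)F)c1`, gives 5200 nM.

Compound 2 stands at the higher of the two numbers: the step of a 2.1-fold higher number from compound 1 to compound 2 (0.32 log units; beyond the scatter) separates it from compound 1, so compound 2 is the weaker of the pair on this read-out. The shared core carries an amide bound to a double-bonded chain, and the aryl group at the far end of that chain is the only part that varies here.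

Compound 3, `COc1ccc(C(=O)c2cc(OC)c(OC)c(OC)c2)cc1NC(=O)/C=C/c1ccc(N)cc1`, has not yet been measured. It differs from compound 2 by 4-aminophenyl in place of 3-(trifluoromethoxy)phenyl on a double-bonded chain carbon bound to a double-bonded chain carbon. For the measured compounds named here, the one measured step that bears on this position, a 2.1-fold higher number from compound 1 to compound 2 (0.32 log units; beyond the scatter), shows that exchanging the aryl group at this place shifts the number modestly, and that the trifluoromethoxy-bearing group gave the higher number. Going by the values given here, only a single step exists, so the direction for the aminophenyl group is uncertain. Compound 3 is therefore expected to land near compound 2, with a modest step in either direction possible, estimated as a 1.5-fold lower number from compound 2 to compound 3 (0.17 log units; within the scatter). The estimate for compound 3 in this assay is 3500 nM, within a range from 1200 nM to 10000 nM.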

Compound 3, half-maximal inhibitory concentration: 5600 nM
Beside the measured number, compound 3's estimate is 1.6-fold (0.20 log units) below it, and the stated range covers the measured number.
By their numbers in this assay, from the lowest: compound 1; then compounds 2 and 3 (each within the scatter of the next).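

In this assay the exchange of 3-(trifluoromethoxy)phenyl for 4-aminophenyl gives a 1.1-fold higher number from compound 2 to compound 3 (0.03 log units; within the scatter), so on this read-out the two groups cannot be told apart, even though the entering group has fewer heavy atoms and carries a hydrogen-bond donor that the leaving group lacks. Measured against 3,4-dimethoxyphenyl, the 4-aminophenyl group gives a 2.2-fold higher number from compound 1 to compound 3 (0.35 log units; beyond the scatter), a modest step beyond the scatter, so the quite different aryl groups of compound 2 and compound 3 read alike and compound 1 alone stands apart with the lowest number. No measurement shown here accounts for why the two groups read alike or why compound 1 stands apart.

The compounds shown leave open whether the lower number of compound 1 needs both methoxy groups, which a 3-methoxyphenyl or 4-methoxyphenyl group at this place would test. They also leave open how a 3-aminophenyl group, with the amine moved, or a 4-carboxyphenyl group, which brings in a carboxylic acid, would compare with compound 3.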